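The source may report more compounds than this note shows. Statements on the series, on what has been measured and on what is new or still open speak of the compounds shown alone.

Measured in a functional assay on MCF7 cells (Homo sapiens) for antiproliferative activity, read by MTT assay, with a stated time of 48 h; a lower number here means a stronger inhibitor, a higher number a weaker inhibitor:
Compound 1 `COc1ccc(-c2c(Nc3ccc(C)cc3)c3ccccc3oc2=O)cc1`: 65300 nM
Compound 2 `COc1ccc(-c2c(Nc3ccc(F)cc3)c3ccc(O)cc3oc2=O)cc1`: 71500 nM
Compound 3 `COc1ccc(-c2c(Nc3ccc(C)c(O)c3)c3ccc(O)cc3oc2=O)cc1`: > 100000 nM

Compound 3 stands at > 100000 nM, which is a limit of the assay and not a number. Among the compounds with values here, it is the one compound at the limit of > 100000 nM in this assay, at which 1 of the 3 values shown sits.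

Compound 4 `COc1ccc(-c2c(Nc3ccc(C)cc3)c3ccc(O)cc3oc2=O)cc1` has not yet been measured. It replaces the hydroxy of compound 3 with hydrogen, turning 3-hydroxy-4-methylphenyl into 4-methylphenyl, on an aromatic carbon ortho to a methyl group: hydrogen in place of hydroxy on an aromatic carbon.

One measured step involves this group, an at least 1.3-fold higher number from compound 2 to compound 3 (0.14 log units; that floor lies within the scatter). It gives only a floor, so it fixes no size for the change. The 4-methylphenyl group also occurs in compound 1, which gives 65300 nM. Compound 4 keeps the core of compound 2, which gives 71500 nM.

A modest step to a lower number is therefore expected in this assay, and it may stay small. The expected step is an at least 1.4-fold lower number from compound 3 to compound 4 (0.15 log units; that floor lies within the scatter). For compound 4 the estimated value is 70000 nM, with an expected range of 35000 nM to 130000 nM.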

Compound 4, half-maximal inhibitory concentration: 85500 nM
Beside the measured number, compound 4's estimate is 1.2-fold (0.09 log units) below it; the range from low to high includes it.
By their numbers in this assay, from the lowest: compounds 1, 2 and 4 (each within the scatter of the next). At a limit, above all of these: compound 3.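

In this assay, taking the hydroxy off the 3-hydroxy-4-methylphenyl group gives an at least 1.1-fold lower number from compound 3 to compound 4 (0.06 log units; that floor lies within the scatter), so the size of this change is still fixed only by a floor. Within the data shown here, compound 3 remains the one compound at a limit, which is not a number: the limit of > 100000 nM in this assay, at which 1 of the 4 values shown sits. Compound 4 does supply a real number for the 4-methylphenyl group, and the two steps it opens, a 1.2-fold higher number from compound 2 to compound 4 (0.08 log units; within the scatter) and a 1.3-fold higher number from compound 1 to compound 4 (0.12 log units; within the scatter), show that neither methyl in place of fluoro nor hydroxy in place of hydrogen on an aromatic carbon moves the value beyond the scatter.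

On these data alone, how far compound 3 really lies from compound 4 stays open. Also open, as far as these compounds go, is whether an amine or a carboxylic acid in place of the hydroxy, ortho to a methyl group, would shift the value beyond the scatter.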